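The source may hold more compounds than are shown below. What is called first, only, known or untested is meant among the compounds shown, and "the series" means these compounds.

Measured compounds in a functional assay on B16-F10 cells (Mus musculus) for inhibition, read by MTT assay, with a stated time of 72 h; a lower number here means a stronger inhibitor, a higher number a weaker inhibitor:
- compound 1 `N#Cc1c(Nc2cccc(C(F)(F)F)c2)nc(SCc2cn(Cc3ccccc3Cl)nn2)nc1-c1ccccc1`: 3710 nM
- compound 2 `COc1ccccc1Nc1nc(SCc2cn(Cc3ccccc3Cl)nn2)nc(-c2ccccc2)c1C#N`: 7860 nM

Compound 2 stands highest of the two numbers in this assay; its nearest neighbour is compound 1, and the step of a 2.1-fold higher number from compound 1 to compound 2 (0.33 log units; beyond the scatter) separates them. Within the data shown here, that step exchanges the group on the nitrogen on an aromatic ring and is the only measured step.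

Compound 3 `N#Cc1c(Nc2ccc(F)cc2)nc(SCc2cn(Cc3ccccc3Cl)nn2)nc1-c1ccccc1` is not yet measured. It differs from compound 2 by 4-fluorophenyl in place of 2-methoxyphenyl on a nitrogen on an aromatic ring. Among the measured compounds shown here, no measured step covers the exchange of 2-methoxyphenyl for 4-fluorophenyl at this nitrogen; the one step known at this position, from compound 1 to compound 2, was of modest size and beyond the scatter, which shows that changes here can move this assay by a modest amount in either direction. A modest shift is therefore expected for compound 3, with the direction uncertain and a wide range around it.

For compound 3 in this assay the expected number is 4500 nM, within the range 1500 nM to 13000 nM, which means an expected step of a 1.7-fold lower number from compound 2 to compound 3 (0.24 log units; within the scatter).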

Compound 3, half-maximal inhibitory concentration: 5340 nM
The estimate for compound 3 lay 1.2-fold (0.07 log units) below the measured number, and the stated range covers the measured number.
By their numbers in this assay, from the lowest: compounds 1, 3 and 2 (each within the scatter of the next, the first and the last beyond it).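

In this assay, the pair carrying 2-methoxyphenyl and 4-fluorophenyl on the nitrogen reads as a 1.5-fold lower number from compound 2 to compound 3 (0.17 log units; within the scatter) and the pair carrying 3-(trifluoromethyl)phenyl and 4-fluorophenyl reads as a 1.4-fold higher number from compound 1 to compound 3 (0.16 log units; within the scatter) in the same assay. Compound 3 therefore cannot be separated from either of the other two, although the earlier pair alone, at a 2.1-fold higher number from compound 1 to compound 2 (0.33 log units; beyond the scatter), had suggested a real difference at this position, and that difference now stands as the only one beyond the scatter among the three substituted phenyl groups. Nothing in the data shown gives a cause for these numbers.

The three phenyl groups differ both in their substituent and in where it sits, so the set shown cannot separate these two variables at this nitrogen. Also open, going by these compounds, is how the series responds to a group there that has no aromatic ring, such as a cyclohexyl ring or a longer alkyl chain, or to a phenyl ring carrying an amine or a carboxylic acid.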